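Carboxamide in place of the amidoxime on the shared core

The compounds below may be only part of what the source reports. "The series", "measured", "known", "first", "only" and "open" are said of these compounds alone.

Measured so far:
- compound 1, `N/C(S)=N/N=C/c1c(Cl)n(C2O[C@H](CO)[C@@H](O)[C@H]2O)c2cc(Cl)c(Cl)cc12`: 65000 nM
- compound 2, `N/C(=N\O)c1c(Cl)n(C2O[C@H](CO)[C@@H](O)[C@H]2O)c2cc(Cl)c(Cl)cc12`: > 100000 nM

In a functional assay on KB cells (Homo sapiens) for cytotoxicity, read by spectrophotometry and crystal violet staining (a lower number here means a stronger inhibitor, a higher number a weaker inhibitor), compound 1 gives 65000 nM. Compound 2 reaches only the limit of the measurement, > 100000 nM, so for compound 2 no number is known, only a limit. Among the compounds with values here, the one step between them, an at least 1.5-fold higher number from compound 1 to compound 2 (0.18 log units; that floor lies within the scatter), therefore also has only a floor, and that floor sits within the scatter; it carries the limit (the limit of > 100000 nM in this assay, at which 1 of the 2 values shown sits).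

Compound 3, `NC(=O)c1c(Cl)n(C2O[C@H](CO)[C@@H](O)[C@H]2O)c2cc(Cl)c(Cl)cc12`, differs from compound 2 by a group of 3 heavy atoms (1 carbon, 1 nitrogen, 1 oxygen; no ring) in place of a group of 4 heavy atoms (1 carbon, 2 nitrogen, 1 oxygen; no ring), on an aromatic carbon. Within the data shown here, no measured step touches this pair directly; the only step at that position is the one from compound 1 to compound 2, and it shows at most that both groups there leave weak inhibitors. The change to the carbamoyl is therefore expected to move the number little in this assay, with a fair chance that compound 3 again ends at the limit.

For compound 3 a value of 120000 nM is estimated in this assay, with a range from 40000 nM to 400000 nM. The step this estimate implies, a step that the limit leaves unreadable from compound 2 to compound 3, is expected to lie within the scatter.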

Compound 3, half-maximal inhibitory concentration: 45000 nM
The estimate for compound 3 lay 2.7-fold (0.43 log units) above the measured number; the range from low to high includes it.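

In this assay, the step to the carbamoyl is an at least 2.2-fold lower number from compound 2 to compound 3 (0.34 log units; beyond the scatter), so the group on this aromatic carbon can change the number, which the earlier step, an at least 1.5-fold higher number from compound 1 to compound 2 (0.18 log units; that floor lies within the scatter), could not show. On these data alone, that step is only a floor and its true size stays unknown because compound 2 sits at a limit: the limit of > 100000 nM in this assay, at which 1 of the 3 values shown sits. The other new step is a 1.4-fold lower number from compound 1 to compound 3 (0.16 log units; within the scatter), so in this assay the carbamoyl and the group of compound 1 cannot be told apart at this position, and the change from compound 2 separates that group from the carbamoyl only on one side of the limit.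

Open, as far as these compounds go, is whether any group on this carbon takes the number well away from the level shared by compound 1 and compound 3; a carboxylic acid, a nitrile or an amine in place of the carbamoyl would test this in this assay. Also open, from the compounds shown here alone, is whether the step to the carbamoyl holds when the chloro group on the neighbouring ring atom gives way to a hydrogen or a methyl group.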